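Moving the methyl on the phenyl group

The source may hold more compounds than are shown below. What is called first, only, known or untested is meant among the compounds shown, and "the series" means these compounds.

Values in a functional assay on DU-145 cells (Homo sapiens) for cytotoxicity, read by sulforhodamine B assay, with a stated time of 48 h; on this read-out higher numbers stand for weaker inhibition and lower numbers for stronger inhibition:
compound 1 `COc1ccc(C2=NO[C@]3(C2)C(=O)O[C@@H]2[C@H]3CC[C@H](C)[C@]3(O)C=CC(=O)[C@@]23C)cc1`: 20000 nM
compound 2 `Cc1ccccc1C1=NO[C@]2(C1)C(=O)O[C@@H]1[C@H]2CC[C@H](C)[C@]2(O)C=CC(=O)[C@@]12C`: 12000 nM

Among the compounds with values here, only these two compounds have numbers so far. Within the data shown here, compound 2, at 12000 nM, lies within the scatter of compound 1, its only neighbour, and the measured step is a 1.7-fold lower number from compound 1 to compound 2 (0.22 log units; within the scatter). Neither compound therefore stands apart on the numbers.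

The next compound is compound 3 `Cc1cccc(C2=NO[C@]3(C2)C(=O)O[C@@H]2[C@H]3CC[C@H](C)[C@]3(O)C=CC(=O)[C@@]23C)c1`, which has the same atoms as compound 2, joined differently: 3-methylphenyl in place of 2-methylphenyl on a carbon with a double bond to nitrogen.

Among the measured compounds shown here, only one measured step bears on this change, a 1.7-fold lower number from compound 1 to compound 2 (0.22 log units; within the scatter). It exchanged 4-methoxyphenyl for 2-methylphenyl on the same carbon and did not leave the scatter. For the measured compounds named here, that is a single case, and no measured compound yet carries 3-methylphenyl, so the basis is thin. Even so, no step beyond the scatter is expected in this assay. The expected step is a 1.1-fold higher number from compound 2 to compound 3 (0.03 log units; within the scatter), with no firm direction. For compound 3 the estimated value is 13000 nM, with an expected range from 6000 nM to 27000 nM.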

Compound 3, half-maximal inhibitory concentration: 28000 nM
The estimate for compound 3 lay 2.2-fold (0.33 log units) below the measured number; the measured number lies above the stated range.
By their numbers in this assay, from the lowest: compounds 2, 1 and 3 (each within the scatter of the next, the first and the last beyond it).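

Exchanging 2-methylphenyl for 3-methylphenyl on the carbon with a double bond to nitrogen leaves the atom count unchanged, yet in this assay it gives a 2.3-fold higher number from compound 2 to compound 3 (0.37 log units; beyond the scatter). The read-out at this position therefore responds to where the methyl sits on the phenyl group, although the step is modest and rests on one pair, something the earlier exchange, which stayed within the scatter, could not show. The exchange of 4-methoxyphenyl for 3-methylphenyl gives a 1.4-fold higher number from compound 1 to compound 3 (0.15 log units; within the scatter), so that pair has no order, and only the two methyl isomers are separated; no measured property accompanies these numbers, and the step between them remains without an explanation.

On these data alone, whether a longer chain in place of the methyl, or an amine or a carboxylic acid on the phenyl group, would move the number further remains open. Also open, as far as these compounds go, is whether the gap between the two methyl isomers would persist in any other cell line, since all of these readings come from a single assay.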